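Replacing a bridged bicycle with tert-butyl on a xanthine-type core

A few compounds are considered here, and "the series" means these few. Any claim that something is new, unique, unknown or untested is made for them only; others in the source may bear on it.

Among the measured compounds shown here, compound 3 `CCCn1c(=O)c2nc([C@H]3CC4C=CC3C4)[nH]c2n(CCC)c1=O` gives 3.4 nM in an assay on cell membranes for binding affinity to adenosine receptor A1 (Cavia porcellus), read by radioligand binding (a higher number here means a weaker inhibitor, a lower number a stronger inhibitor), the lowest of the three numbers measured so far. Compound 2 `CCCn1c(=O)c2nc(CC(C)(C)C)[nH]c2n(CCC)c1=O` gives 49 nM in this assay, and compound 1 `CC1(Nc2ncnc3c2ncn3C2O[C@H](CO)[C@@H](O)[C@H]2O)CCCCC1` gives 70 nM. Compound 4 `CCCn1c(=O)c2nc(C(C)(C)C)[nH]c2n(CCC)c1=O` has not yet been measured. It differs from compound 3 by a group of 4 heavy atoms (4 carbon; no ring) in place of a group of 7 heavy atoms (7 carbon; 2 five-membered non-aromatic rings of carbon only), on an aromatic carbon. For the measured compounds named here, the one measured step that bears on this change is a 14-fold lower number from compound 2 to compound 3 (1.16 log units; beyond the scatter), in which the same bicyclic group entered in place of a chain of the same kind as the tert-butyl now entering. Removing that bicycle is therefore expected to undo most of that gain, so compound 4 is expected to land near compound 2, with an estimated step of a 12-fold higher number from compound 3 to compound 4 (1.07 log units; beyond the scatter). The estimate for compound 4 is 40 nM, within 12 nM to 130 nM.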

Compound 4, inhibition constant: 31 nM
Compound 4: middle estimate off by 1.3-fold (0.11 log units), on the high side; the measured number falls inside the stated range.
By their numbers in this assay, from the lowest: compound 3; then compounds 4, 2 and 1 (each within the scatter of the next, the first and the last beyond it).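

In this assay, tert-butyl and neopentyl on this aromatic carbon cannot be told apart, with a 1.6-fold lower number from compound 2 to compound 4 (0.20 log units; within the scatter) as the step between them. The bridged bicycle stands apart from tert-butyl as well, with a 9.1-fold higher number from compound 3 to compound 4 (0.96 log units; beyond the scatter) as the step, so the low number of compound 3 now compares with two ring-free groups rather than one. No measurement shown gives a reason for this difference. Still open, going by these compounds, is whether the rings, the double bond or the extra carbon atoms matter, and how a single cyclopentyl ring or a saturated bicycle would compare on this carbon.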